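This account rests on a few compounds, and the source may have more. Where it says the series, first, only, none or still open, it means among the compounds named here.

Compound 1 `CC(C)C(Nc1nnc[nH]1)c1ccc(-c2ccc3cccc(F)c3c2)[nH]c1=O` is the starting point. In an ADME assay on microsomes from liver (Homo sapiens) for metabolic stability (a lower number here means that the compound disappears faster, a higher number that the compound lasts longer), compound 1 gives > 3 h, which is a limit of the assay rather than a number (the limit of > 3 h in this assay, at which 1 of the 2 values shown sits). Compound 2 `CC(C)C(c1ccc(-c2ccc3cccc(F)c3c2)[nH]c1=O)N1CCCCC1=O` carries a 2-oxopiperidin-1-yl in place of the (4H-1,2,4-triazol-3-yl)amino; in this assay compound 2 gives 0.183 h, and the step is an at least 16-fold lower number from compound 1 to compound 2 (1.21 log units; beyond the scatter). Compound 3 `CC(C)C(/C=C1\CCNC1=O)c1ccc(-c2ccc3cccc(F)c3c2)[nH]c1=O` differs from compound 1 by a group of 7 heavy atoms (5 carbon, 1 nitrogen, 1 oxygen; one five-membered non-aromatic ring with 1 hetero atom) in place of a group of 6 heavy atoms (2 carbon, 4 nitrogen; one five-membered aromatic ring with 3 hetero atoms), on a saturated chain carbon bound to an aromatic carbon and a saturated chain carbon. Here too the (4H-1,2,4-triazol-3-yl)amino leaves and a five-membered non-aromatic ring with 1 hetero atom enters, so a downward step is expected, guided by an at least 16-fold lower number from compound 1 to compound 2 (1.21 log units; beyond the scatter). The expected step is an at least 6.0-fold lower number from compound 1 to compound 3 (0.77 log units; beyond the scatter). Compound 3 is estimated to give 0.5 h, within 0.15 h to 1.6 h.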

Compound 3, half-life: 0.713 h
Compound 3: the middle estimate sits 1.4-fold (0.15 log units) below what was measured; the range from low to high includes it.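

In this assay, a second replacement of the (4H-1,2,4-triazol-3-yl)amino on this saturated chain carbon also lowers the number, with an at least 4.2-fold lower number from compound 1 to compound 3 (0.62 log units; beyond the scatter), so the drop is not confined to compound 2. The replacing groups also differ from each other, with a 3.9-fold higher number from compound 2 to compound 3 (0.59 log units; beyond the scatter). The value of compound 1 is a limit rather than a number: the limit of > 3 h in this assay, at which 1 of the 3 values shown sits.

On these data alone, whether a plain amine or an imidazole ring on this carbon would keep the number high remains open. So does how far compound 1 truly lies from compound 3.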